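The compounds below may be only part of what the source reports. "The series", "measured", "known", "first", "only" and "open" are said of these compounds alone.

In an assay on cells with melanin-concentrating hormone receptor 1 (Homo sapiens) as the target, read by radioligand binding (on this read-out lower numbers stand for stronger inhibition and higher numbers for weaker inhibition), compound 3 `Nc1ccc2cccc(OCC3CC3)c2n1` stands only at a limit of the assay, > 2000 nM, and not at a number. Compound 1 `CC#CCCOc1cccc2ccc(N)nc12` likewise sits at a limit, giving > 2000 nM in this assay. Compound 2 `CC1CC1COc1cccc2ccc(N)nc12` is the only one of the three with a number, 1640 nM in this assay. Compound 1 and compound 3 share the same limit (the limit of > 2000 nM in this assay, at which 2 of the 3 values shown sit). The step of an at least 1.2-fold lower number from compound 1 to compound 2 (0.08 log units; that floor lies within the scatter) and the step of an at least 1.2-fold higher number from compound 2 to compound 3 (0.08 log units; that floor lies within the scatter) both have floors within the scatter, while the step that the two limits leave unreadable from compound 1 to compound 3 stays unreadable between two limits. Compound 4 `CCCC(C)Oc1cccc2ccc(N)nc12` carries 1-methylbutyl in place of cyclopropylmethyl on an oxygen on an aromatic ring, so the five-carbon group without a ring takes the place of the four-carbon group with its three-membered ring. All measured steps around this position fall within the scatter or cannot be read, so no step beyond the scatter is expected in this assay for the change from compound 3 to compound 4, and the estimated step is a step that the limit leaves unreadable from compound 3 to compound 4. Compound 4 is therefore expected near 2500 nM in this assay, with a range from 800 nM to 8000 nM, and a real chance that only a limit is reported.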

Compound 4, half-maximal inhibitory concentration: 105 nM
Compound 4: the middle estimate sits 24-fold (1.38 log units) above what was measured; the measured number lies below the stated range.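

In this assay, this position proved able to carry a step well beyond the scatter, which no earlier pair had shown: 1-methylbutyl in place of cyclopropylmethyl gives an at least 19-fold lower number from compound 3 to compound 4 (1.27 log units; beyond the scatter). Set against (2-methylcyclopropyl)methyl, the same group gives a 16-fold lower number from compound 2 to compound 4 (1.19 log units; beyond the scatter), the only one of these steps with a number at both ends, and against pent-3-yn-1-yl it gives an at least 19-fold lower number from compound 1 to compound 4 (1.27 log units; beyond the scatter). The steps from compound 1 and compound 3 are only floors because both compounds sit at a limit: the limit of > 2000 nM in this assay, at which 2 of the 4 values shown sit.

On these data alone, whether the step belongs to the loss of the ring or to the 1-methylbutyl chain itself stays open. Also open, as far as these compounds go, is how isopropyl, a longer branched chain or a chain ending in an amine would read at this position.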